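Trifluoromethyl in place of phenyl on compound 2

A few compounds are considered here, and "the series" means these few. Any claim that something is new, unique, unknown or untested is made for them only; others in the source may bear on it.

Measured in a functional assay on K562 cells (Homo sapiens) for inhibition, read by sulforhodamine B assay, with a stated time of 48 h, tested at 10 uM; on this read-out higher numbers stand for more inhibition of growth at the one concentration tested and lower numbers for less inhibition of growth:
Compound 1 `CC(=O)c1ccc(Nc2ccnc(SCC(=O)c3ccc(Br)cc3)n2)cc1`: 30%
Compound 2 `CC(=O)c1cccc(Nc2ccnc(SCC(=O)c3ccc(-c4ccccc4)cc3)n2)c1`: 16%
Compound 3 `CC(=O)c1ccc(Nc2ccnc(SCC(=O)c3ccc(-c4ccccc4)cc3)n2)cc1`: 10%

Compound 2, at 16%, stands well under compound 1 in this small set, and its step to the remaining compound is a number 6 percentage points lower from compound 2 to compound 3 (within the scatter). That step, 4-acetylphenyl in place of 3-acetylphenyl, suggests that the acetyl position matters little here.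

Compound 4 `CC(=O)c1cccc(Nc2ccnc(SCC(=O)c3ccc(C(F)(F)F)cc3)n2)c1` is still unmeasured. Its change from compound 2 is trifluoromethyl in place of phenyl on an aromatic carbon.

Going by the values given here, the closest precedent concerns the same place, with phenyl entering and bromo leaving: a number 20 percentage points lower from compound 1 to compound 3 (beyond the scatter). Among the compounds with values here, compound 4 goes the opposite way, losing phenyl to a small group, although no measured compound carries trifluoromethyl, so the precedent is only partial. A modest rise in this assay is therefore expected, of about the size of that earlier step but less certain. The expected step is a number 12 percentage points higher from compound 2 to compound 4 (beyond the scatter). Compound 4 is estimated at 28%, with an expected range of 12% to 45%.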

Compound 4, percent growth inhibition at one concentration: 29%
The estimate for compound 4 lay 1 percentage points below the measured number; measured number inside the range.
By their numbers in this assay, from the lowest: compounds 3 and 2 (each within the scatter of the next); then compounds 4 and 1 (each within the scatter of the next).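

In this assay, trifluoromethyl in place of phenyl gives a number 13 percentage points higher from compound 2 to compound 4 (beyond the scatter). Earlier, phenyl at this place had been compared only with bromo and only on compounds carrying 4-acetylphenyl, in a number 20 percentage points lower from compound 1 to compound 3 (beyond the scatter); the new step shows the number also moving away from phenyl's low reading on a compound carrying 3-acetylphenyl, and with a different group entering, one with no ring and fewer heavy atoms. No available evidence bears on why the number changes at this position.

The compounds shown leave open whether it is the phenyl ring as such that goes with the lower numbers, since a pyridine ring or a cyclohexyl ring at this place would be needed to test that. They also leave open how an amine, a carboxylic acid or a methoxy group would read here.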